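Replacing phenyl by 4-fluorobenzyl on the amide nitrogen

The compounds below may be only part of what the source reports. "The series", "measured", "known", "first", "only" and "open" are said of these compounds alone.

Compound 1 `O=C(NCc1cccc(F)c1)c1nc([N+](=O)[O-])c(Sc2c(Cl)cncc2Cl)s1`: 1350 nM
Compound 2 `CC(=O)c1nc([N+](=O)[O-])c(Sc2ccc(F)cc2F)s1`: 6120 nM
Compound 3 `O=C(Nc1ccccc1)c1nc([N+](=O)[O-])c(Sc2c(Cl)cncc2Cl)s1`: 40500 nM

In an assay on isolated protein for inhibition of ubiquitin carboxyl-terminal hydrolase 7 (Homo sapiens), read by fluorescence, with stated times of 30 min and 3 h (on this read-out higher numbers stand for weaker inhibition and lower numbers for stronger inhibition), compound 3 gives 40500 nM, the highest of the three numbers. Compound 2 gives 6120 nM and compound 1 gives 1350 nM, both well below it. Compound 4 `O=C(NCc1ccc(F)cc1)c1nc([N+](=O)[O-])c(Sc2c(Cl)cncc2Cl)s1` differs from compound 3 by 4-fluorobenzyl in place of phenyl on an amide-type nitrogen. For the measured compounds named here, the one measured step that bears on this change is a 30-fold higher number from compound 1 to compound 3 (1.48 log units; beyond the scatter); the move to compound 4 runs in the opposite direction, with 4-fluorobenzyl in place of 3-fluorobenzyl as the entering group. A large downward step in this assay is therefore expected, a 27-fold lower number from compound 3 to compound 4 (1.43 log units; beyond the scatter), with compound 1 as the closest measured guide. Compound 4 is estimated at 1500 nM, with a range from 500 nM to 5000 nM.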

Compound 4, half-maximal inhibitory concentration: 2650 nM
Compound 4: the middle estimate sits 1.8-fold (0.25 log units) below what was measured; measured number inside the range.
By their numbers in this assay, from the lowest: compounds 1 and 4 (each within the scatter of the next); then compound 2; then compound 3.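

In this assay, the large change on leaving phenyl is not tied to one fluorobenzyl group: 4-fluorobenzyl gives a 15-fold lower number from compound 3 to compound 4 (1.18 log units; beyond the scatter), in line with what compound 1 with its 3-fluorobenzyl had suggested. Moving the fluorine gives a 2.0-fold higher number from compound 1 to compound 4 (0.29 log units; within the scatter), which lies within the scatter, so the two fluorobenzyl amides cannot be told apart here. Nothing measured here explains these steps.

Open, as far as these compounds go, is whether the fluorine matters at all: a plain benzyl group on the amide nitrogen would test that. Also open, from the compounds shown here alone, is whether a longer chain, such as 2-phenylethyl, would hold the same level.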